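Swapping the Acyl Cap on a Fibronectin-Receptor Inhibitor

The compounds below may be only part of what the source reports. "The series", "measured", "known", "first", "only" and "open" are said of these compounds alone.

Compound 1 `COc1ccnc(NC[C@@H]2C[C@@H](OCC(=O)NC[C@H](NC(=O)C3(C)CCCCC3)C(=O)O)CN2C(=O)OCc2ccccc2)c1` gives 0.8 nM in an assay on a protein complex for inhibition of integrin alpha-5/beta-1 (Homo sapiens), read by ELISA (on this read-out lower numbers stand for stronger inhibition and higher numbers for weaker inhibition), the lowest of the two numbers recorded; compound 2 `Cc1cc(C)c(S(=O)(=O)N[C@@H](CNC(=O)CO[C@@H]2C[C@@H](CNc3ccccn3)N(C(=O)CC(C)(C)C)C2)C(=O)O)c(C)c1` gives 6 nM in this assay, a number that stands beyond the scatter above it. Compound 3 `COc1ccnc(NC[C@@H]2C[C@@H](OCC(=O)NC[C@H](NC(=O)c3c(C)cc(C)cc3C)C(=O)O)CN2C(=O)OCc2ccccc2)c1` differs from compound 1 by 2,4,6-trimethylphenyl in place of 1-methylcyclohexyl on a carbonyl carbon, with the rest of the core untouched. Going by the values given here, no measured pair differs only at this position, so the step is judged from the two values alone. Compound 3 is expected to move only modestly, at most a small loss, by a 1.9-fold higher number from compound 1 to compound 3 (0.27 log units; within the scatter). Compound 3 is therefore estimated at 1.5 nM, within 0.5 nM to 5 nM.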

Compound 3, half-maximal inhibitory concentration: 0.54 nM
The estimate for compound 3 lay 2.8-fold (0.44 log units) above the measured number; the range from low to high includes it.
By their numbers in this assay, from the lowest: compounds 3 and 1 (each within the scatter of the next); then compound 2.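

On a carbonyl carbon whose other neighbour is an amide-type nitrogen, 2,4,6-trimethylphenyl replaces 1-methylcyclohexyl with a 1.5-fold lower number from compound 1 to compound 3 (0.17 log units; within the scatter) in this assay and the two values cannot be told apart. At this position, in this one pair, an aromatic carbon ring of 9 heavy atoms and a non-aromatic carbon ring of 7 read alike. No supporting data speak to the reason for this result. The compounds shown leave open whether a cyclopropyl group or a piperidine ring on this carbonyl carbon would read the same way.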